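Swapping bromo for trifluoromethyl on the sulfonyl aryl ring

This account rests on a few compounds, and the source may have more. Where it says the series, first, only, none or still open, it means among the compounds named here.

Three closely related compounds have been tested in a functional assay on HeLa cells (Homo sapiens) for antiproliferative activity, read by MTT assay, with a stated time of 24 h; on this read-out higher numbers stand for weaker inhibition and lower numbers for stronger inhibition. Compound 1 `Cc1ccc(-c2nn(-c3ccccc3)cc2-c2nc3ccccc3n2S(=O)(=O)c2ccc(Br)cc2)cc1` gives 2340 nM in this assay. Compound 2 `Cc1ccc(-c2nn(-c3ccccc3)cc2-c2nc3ccccc3n2S(=O)(=O)c2ccc(C(F)(F)F)cc2)cc1` differs from compound 1 by trifluoromethyl in place of bromo on an aromatic carbon; in this assay compound 2 gives 1520 nM, and the step is a 1.5-fold lower number from compound 1 to compound 2 (0.19 log units; within the scatter). Compound 3 `O=S(=O)(c1ccc(Br)cc1)n1c(-c2cn(-c3ccccc3)nc2-c2ccc(C(F)(F)F)cc2)nc2ccccc21` carries a different core, and the difference between the two cores is trifluoromethyl in place of methyl on an aromatic carbon. In this assay compound 3 gives 1860 nM, a move of a 1.3-fold lower number from compound 1 to compound 3 (0.10 log units; within the scatter). All three values sit within the scatter of one another, so no ordering among them can be claimed.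

Compound 4 `O=S(=O)(c1ccc(C(F)(F)F)cc1)n1c(-c2cn(-c3ccccc3)nc2-c2ccc(C(F)(F)F)cc2)nc2ccccc21` has not yet been measured. It stands to compound 3 as compound 2 stands to compound 1: the change is trifluoromethyl in place of bromo on an aromatic carbon, and its description matches the earlier one word for word, so it is the same change, here made on the core of compound 3 rather than that of compound 1. Among these compounds that change occurs twice, and only one instance has a measured result.

For the measured compounds named here, compound 4 is therefore expected to show a 1.5-fold lower number from compound 3 to compound 4 (0.17 log units; within the scatter) in this assay, because the single measured instance of the same change gave a 1.5-fold lower number from compound 1 to compound 2 (0.19 log units; within the scatter). That expected step is small and lies within the scatter, so the estimate is correspondingly uncertain. The estimate for compound 4 is 1250 nM, with an expected range from 620 nM to 2500 nM.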

Compound 4, half-maximal inhibitory concentration: 970 nM
Beside the measured number, compound 4's estimate is 1.3-fold (0.11 log units) above it, within the range that was stated.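

In this assay, trifluoromethyl in place of bromo on the core of compound 3 gives a 1.9-fold lower number from compound 3 to compound 4 (0.28 log units; within the scatter), and this step is close to the one seen earlier on the core of compound 1: the same change on two cores in this assay, a 1.5-fold lower number (0.19 log units; within the scatter) from compound 1 to compound 2 and a 1.9-fold lower number (0.28 log units; within the scatter) from compound 3 to compound 4, 1.2-fold (0.10 log units) apart, within the scatter of two such steps

Trifluoromethyl in place of methyl, now with the trifluoromethyl-bearing sulfonyl aryl ring held constant, gives a 1.6-fold lower number from compound 2 to compound 4 (0.20 log units; within the scatter), and it too shows no detectable dependence on its context: the same change on two cores in this assay, a 1.3-fold lower number (0.10 log units; within the scatter) from compound 1 to compound 3 and a 1.6-fold lower number (0.20 log units; within the scatter) from compound 2 to compound 4, 1.2-fold (0.10 log units) apart, within the scatter of two such steps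

Within these four compounds, then, neither change gives any sign of behaving differently from one core to the other, but every step lies within the scatter, so the data do not show that either change has a real effect in this assay, and two instances of each cannot show that it would carry to other cores in the series.

The compounds shown carry only bromo, trifluoromethyl and methyl at the two varied places, so what an amine, a carboxylic acid or a longer chain would do there remains open. As far as these compounds go, it also remains open whether any change at these places can move the number beyond the scatter.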